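Chain extension on the amide of compound 3

The source may report more compounds than this note shows. Statements on the series, on what has been measured and on what is new or still open speak of the compounds shown alone.

Compound 1, `CCCCCCCCCCCCNC(=O)[C@@H](NC(=O)c1cccs1)[C@@H](C)O`, in a functional assay on SiHa cells (Homo sapiens) for cytotoxicity, read by MTT assay, with a stated time of 48 h (a lower number here means a stronger inhibitor, a higher number a weaker inhibitor), gives 23900 nM.
Compound 2, `CCCCCCCCCCCCNC(=O)[C@@H](NC(=O)c1cc2ccccc2o1)[C@@H](C)O`, gives 12900 nM.
Compound 3, `CCCCCCCCCCCCNC(=O)[C@@H](NC(=O)/C=C/c1ccccc1)[C@@H](C)O`, gives only a limit, > 200000 nM.

Going by the values given here, compound 3 thus stands at a limit of the assay, not at a number; it is the one value sitting at the limit of > 200000 nM in this assay, at which 1 of the 3 values shown sits. Every step measured so far alters the group on the carbonyl carbon: a 1.9-fold lower number from compound 1 to compound 2 (0.27 log units; within the scatter), an at least 8.3-fold higher number from compound 1 to compound 3 (0.92 log units; beyond the scatter), an at least 15-fold higher number from compound 2 to compound 3 (1.19 log units; beyond the scatter). Compound 4, `CCCCCCCCCCCCCCCCCCNC(=O)[C@@H](NC(=O)/C=C/c1ccccc1)[C@@H](C)O`, differs from compound 3 by hexyl in place of hydrogen on a saturated chain carbon, ten or more bonds along the chain from an amide-type nitrogen. Among the compounds with values here, no measured step touches the chain, so none bears on this change or gives it a direction. The step from compound 3 to compound 4 is expected to be a number no higher from compound 3 to compound 4 (the limit leaves the size open). Compound 4 is therefore estimated at 200000 nM, within a range of 80000 nM to 500000 nM, most likely again as a limit.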

Compound 4, half-maximal inhibitory concentration: 35900 nM
The estimate for compound 4 lay 5.6-fold (0.75 log units) above the measured number, and the stated range ends above it.
By their numbers in this assay, from the lowest: compounds 2, 1 and 4 (each within the scatter of the next, the first and the last beyond it). At a limit, above all of these: compound 3.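

In this assay, going by these compounds alone, the chain proves responsive: hexyl in place of hydrogen on a saturated chain carbon, ten or more bonds along the chain from an amide-type nitrogen, gives an at least 5.5-fold lower number from compound 3 to compound 4 (0.74 log units; beyond the scatter) and is the first measured step at this position. With compound 4 reading as a number, the 2-phenylethenyl group on the carbonyl carbon does not by itself hold a compound at the limit. Compound 3 remains a limit, not a number, so the full size of the step stays open: the limit of > 200000 nM in this assay, at which 1 of the 4 values shown sits.

On these data alone, whether a longer chain than that of compound 4, or an amine or a carboxylic acid in place of the chain, shifts the number further remains open. So does the effect of hexyl with thiophen-2-yl or 1-benzofuran-2-yl on the carbonyl carbon.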